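Cyclopentyl in place of triazolyl on the shared core

The source may hold more compounds than are shown below. What is called first, only, known or untested is meant among the compounds shown, and "the series" means these compounds.

Compound 2 `c1nc(Nc2nncc3cncn23)n[nH]1` gives 46000 nM in a functional assay for inhibition, with Homo sapiens as the target; on this read-out higher numbers stand for weaker inhibition and lower numbers for stronger inhibition. On the numbers shown it holds the lower of the two numbers, and compound 3 `C=CCSc1nncc2cnc(C)n12` gives 61000 nM in this assay, a gap that stays within the scatter. Compound 1 `CNc1nncc2cncn12` gives only a limit, > 48000 nM in this assay. Going by the values given here, the one measured step from compound 1 to compound 2, an at least 1.0-fold lower number from compound 1 to compound 2 (0.01 log units; that floor lies within the scatter), replaces methyl with the triazolyl ring on a nitrogen on an aromatic ring; its size is set by the limit of > 48000 nM in this assay, at which 1 of the 3 values shown sits, so it shows no real change.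

Compound 4 `c1ncn2c(NC3CCCC3)nncc12` differs from compound 2 in that same place: cyclopentyl in place of 1H-1,2,4-triazol-3-yl on a nitrogen on an aromatic ring. Among the compounds with values here, the only measured step that bears on this nitrogen is the one from compound 1 to compound 2, which was flat within the scatter, so it gives no sign that what sits on this nitrogen moves the number in this assay in either direction. Compound 4 is therefore expected to change by about a 1.1-fold higher number from compound 2 to compound 4 (0.04 log units; within the scatter) from compound 2, a step that does not go beyond the scatter. The estimate for compound 4 in this assay is 50000 nM, with a range from 20000 nM to 150000 nM.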

Compound 4, half-maximal inhibitory concentration: > 48000 nM
Compound 4: only a limit was reported; the forecaster's own chance of this, stated with the estimate: 40%; the middle value does not contradict the limit.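

In this assay compound 4 returns only a limit, > 48000 nM. Setting cyclopentyl, a non-aromatic ring of carbon only with 0 hydrogen-bond donors and 0 hydrogen-bond acceptors, in place of 1H-1,2,4-triazol-3-yl on this nitrogen gives an at least 1.0-fold higher number from compound 2 to compound 4 (0.01 log units; that floor lies within the scatter), so this second change at the position also shows no real movement, and its size is fixed by a limit: the limit of > 48000 nM in this assay, at which 2 of the 4 values shown sit. The step between compound 1 and compound 4 cannot be read, as both values are limits, so methyl and cyclopentyl cannot be ranked against each other, and among the compounds changed on this nitrogen only compound 2 carries a number rather than a limit.

The compounds shown leave open whether a primary amine, a carboxylic acid or a longer alkyl chain on this nitrogen would give a number in this assay that lies beyond the scatter from compound 2. They also leave open whether a phenyl ring in this place, a six-membered aromatic ring of carbon only, would give a number at all rather than a limit.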